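A few compounds are considered here, and "the series" means these few. Any claim that something is new, unique, unknown or untested is made for them only; others in the source may bear on it.

Measured compounds:
compound 1, `CC(C)(C)CCn1nc(-c2cccs2)c(O)c(C2=NS(=O)(=O)c3cc(OCC(N)=O)ccc3N2)c1=O`: 0.35 h
compound 2, `Cc1ccc(-c2nn(CCC3CC3)c(=O)c(C3=NS(=O)(=O)c4cc(OCC(N)=O)ccc4N3)c2O)s1`: 0.7 h

Both compounds were tested in an in vitro ADME assay on microsomes from liver (Homo sapiens) for metabolic stability; on this read-out lower numbers stand for a shorter-lived compound and higher numbers for a longer-lived compound. In this assay compound 2 gives 0.7 h. Compound 1 gives 0.35 h. These two numbers lie within the usual scatter of one another, so the data do not separate the two compounds.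

Compound 3, `Cc1ccc(-c2nn(CCC(C)(C)C)c(=O)c(C3=NS(=O)(=O)c4cc(OCC(N)=O)ccc4N3)c2O)s1`, has not yet been measured. It differs from compound 2 in a single place: tert-butyl in place of cyclopropyl on a saturated chain carbon, two bonds along the chain from an aromatic nitrogen. Among the compounds with values here, no measured pair shows this exact change, so there is nothing from which its size could be read. Compound 1 shares the 3,3-dimethylbutyl chain with compound 3 but differs from it in a second place as well, so the two differences cannot be pulled apart. The step is therefore expected to be small, with a 1.3-fold lower number from compound 2 to compound 3 (0.10 log units; within the scatter) anticipated as a change not beyond the scatter. Compound 3 is estimated at 0.55 h, with a range from 0.25 h to 1.2 h.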

Compound 3, half-life: 0.75 h
For compound 3 the middle estimate is 1.4-fold (0.13 log units) below the measured one; the measured number falls inside the stated range.
By their numbers in this assay, from the lowest: compounds 1, 2 and 3 (each within the scatter of the next, the first and the last beyond it).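

In this assay, tert-butyl in place of cyclopropyl on a saturated chain carbon, two bonds along the chain from an aromatic nitrogen, gives a 1.1-fold higher number from compound 2 to compound 3 (0.03 log units; within the scatter), so at this position the data do not separate the ringed chain end from the branched one. Compound 3 also forms a single-change pair with compound 1: methyl in place of hydrogen on an aromatic carbon gives a 2.1-fold higher number from compound 1 to compound 3 (0.33 log units; beyond the scatter), a modest step that lies beyond the scatter. Nothing measured here accounts for either step.

From the compounds shown here alone, it remains open how this read-out responds at the same chain position to an end group such as an amine or a carboxylic acid, or to a longer chain. Within the data shown here, it is also open whether the methyl step holds on the 2-cyclopropylethyl chain, as only one pair shows it.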